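Ethoxycarbonyl in Place of Sulfamoyl: What Compound 4 Might Give

The compounds below may be only part of what the source reports. "The series", "measured", "known", "first", "only" and "open" are said of these compounds alone.

Compound 1 `CC(=O)c1cccc(NC2=CC(=O)c3ncncc3C2=O)c1` gives 5200 nM in a functional assay on BXPC-3 cells (Homo sapiens) for cytotoxicity, read by MTT assay, with a stated time of 72 h; a lower number here means a stronger inhibitor, a higher number a weaker inhibitor.
Compound 2 `O=C1C(Nc2ccc(Oc3ccccc3)cc2)=CC(=O)c2ncncc21` gives 3600 nM in this assay.
Compound 3 `NS(=O)(=O)c1ccc(NC2=CC(=O)c3ncncc3C2=O)cc1` gives only a limit of the assay in this assay, > 10000 nM.

Compound 3 therefore stands at the weak end of the three measured compounds, with no number of its own: the limit of > 10000 nM in this assay, at which 1 of the 3 values shown sits. For the measured compounds named here, the one step that has been measured into it, an at least 2.7-fold higher number from compound 2 to compound 3 (0.44 log units; beyond the scatter), shows that placing sulfamoyl on the aromatic carbon cost potency relative to phenoxy.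

Compound 4 `CCOC(=O)c1ccc(NC2=CC(=O)c3ncncc3C2=O)cc1` differs from compound 3 in one place: ethoxycarbonyl in place of sulfamoyl on an aromatic carbon. Going by the values given here, no measured step pairs sulfamoyl with ethoxycarbonyl directly, so the expectation rests on the two compounds that return a number rather than a limit: compound 1 gives 5200 nM and compound 2 gives 3600 nM, which shows that an aryl substituent other than sulfamoyl can return a number, and on the weakening seen in an at least 2.7-fold higher number from compound 2 to compound 3 (0.44 log units; beyond the scatter) when sulfamoyl entered.

Compound 4 is therefore expected to give 6000 nM in this assay, within a range of 2500 nM to 15000 nM. The step this implies, an at least 1.6-fold lower number from compound 3 to compound 4 (0.22 log units; that floor lies within the scatter), is an estimate only; a value that again sits at the limit would not be surprising for compound 4.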

Compound 4, half-maximal inhibitory concentration: 5900 nM
Compound 4: the middle estimate sits 1.0-fold (0.01 log units) above what was measured; the measured number falls inside the stated range.
By their numbers in this assay, from the lowest: compounds 2, 1 and 4 (each within the scatter of the next). At a limit, above all of these: compound 3.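

At this place, an aromatic carbon para to a large group, ethoxycarbonyl returns a number in this assay where sulfamoyl did not, and the change reads as an at least 1.6-fold lower number from compound 3 to compound 4 (0.22 log units; that floor lies within the scatter). Compound 3 still has no number of its own, only a limit of the assay: the limit of > 10000 nM in this assay, at which 1 of the 4 values shown sits. Against phenoxy at the same place, ethoxycarbonyl gives a 1.6-fold higher number from compound 2 to compound 4 (0.21 log units; within the scatter), so the two groups are not told apart here, and the weakening seen with sulfamoyl is not simply what follows whenever phenoxy leaves this place.

On these data alone, how much ethoxycarbonyl truly gains over sulfamoyl stays open, since one end of that comparison is a limit and the step gives only a floor. Also open, as far as these compounds go, is what part of ethoxycarbonyl lets this place return a number, which a carboxylic acid, a primary amide or a longer chain on the ester at the same carbon could begin to show.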